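This account rests on a few compounds, and the source may have more. Where it says the series, first, only, none or still open, it means among the compounds named here.

In an assay on L1.2 cells for binding affinity to C-C chemokine receptor type 8 (Homo sapiens) (a lower number here means a stronger inhibitor, a higher number a weaker inhibitor), compound 3 `Cc1ccccc1C(=O)Nc1ccc(S(=O)(=O)NC2CCN(C(=O)CN)CC2)c2ccccc12` gives 4.1 nM, the lowest of the numbers to hand. Compound 2 `O=C(Nc1ccc(S(=O)(=O)N2CCOCC2)c2ccccc12)c1ccccc1` gives 7750 nM in this assay. Compound 1 `CCN(CC)S(=O)(=O)c1ccc(NC(=O)c2ccccc2)c2ccccc12` reaches only > 30000 nM in this assay, which is a limit and not a number (the limit of > 30000 nM in this assay, at which 1 of the 3 values shown sits). For the measured compounds named here, the one step between measured compounds, an at least 3.8-fold lower number from compound 1 to compound 2 (0.58 log units; beyond the scatter), sits on the sulfonyl sulfur and says nothing about the other end of the molecule. Compound 4 `Cc1ccccc1C(=O)Nc1ccc(S(=O)(=O)NC2CCN(C(=O)NC(C)C)CC2)c2ccccc12` differs from compound 3 only on the carbonyl carbon whose other neighbour is an amide-type nitrogen in a ring: isopropylamino in place of aminomethyl on a carbonyl carbon. No measured pair changes this part of the series, so the step from compound 3 to compound 4 has no precedent among the numbers shown and the expectation rests on the size of the change alone. The exchange is expected to cost modestly in this assay, with a 2.9-fold higher number from compound 3 to compound 4 (0.47 log units; beyond the scatter) the estimated size. For compound 4 the expected value in this assay is 12 nM, within 2.5 nM to 60 nM.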

Compound 4, inhibition constant: 77.7 nM
Beside the measured number, compound 4's estimate is 6.5-fold (0.81 log units) below it; the whole stated range lies below it.
By their numbers in this assay, from the lowest: compound 3; then compound 4; then compound 2. At a limit, above all of these: compound 1.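

In this assay, for the compounds shown here, isopropylamino in place of aminomethyl on a carbonyl carbon gives a 19-fold higher number from compound 3 to compound 4 (1.28 log units; beyond the scatter) and is the first measured step at this end of the molecule, showing that the group on this carbonyl carbon matters to the number. The entering group has more heavy atoms than the leaving one and lacks its hydrogen-bond acceptor, and a single pair cannot separate these two differences. Nothing among the data shown accounts for the size of this step.

Still open, going by these compounds, is whether the loss follows the added carbons or the change of group type, which a methylamino group or a longer aminoalkyl chain such as 2-aminoethyl on the same carbonyl carbon could help to separate. A dimethylaminomethyl group would test how far the free amine hydrogens of aminomethyl count.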